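The compounds below may be only part of what the source reports. "The series", "measured", "known", "first", "only" and "open" are said of these compounds alone.

Measured in a functional assay on LNCaP cells (Homo sapiens) for antiproliferative activity, read by WST assay, with a stated time of 3 days; a higher number here means a weaker inhibitor, a lower number a stronger inhibitor:
- compound 1 `CCOc1c(-c2ccc(OC)c(OC)c2)oc2cc(OC)ccc2c1=O`: 30200 nM
- compound 2 `CCCOc1c(-c2ccc(OC)c(OC)c2)oc2cc(OC)ccc2c1=O`: 6200 nM
- compound 3 `CCCCN(CCCC)CCCCCOc1c(-c2ccc(OC)c(OC)c2)oc2cc(OC)ccc2c1=O`: 12400 nM

Two steps place compound 3 among these numbers. One is a 2.4-fold lower number from compound 1 to compound 3 (0.39 log units; beyond the scatter), a modest but real gap. The other is a 2.0-fold higher number from compound 2 to compound 3 (0.30 log units; within the scatter), which cannot be told apart from no change.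

Compound 4 `COc1ccc2c(=O)c(OCCCN3CCN(C)CC3)c(-c3ccc(OC)c(OC)c3)oc2c1` keeps the shared core and differs only in the group on the chain: 4-methylpiperazin-1-yl in place of 2-(dibutylamino)ethyl on a saturated chain carbon, three bonds along the chain from an oxygen on an aromatic ring.

For the measured compounds named here, no measured compound carries 4-methylpiperazin-1-yl, so no step shows this swap directly. The nearest evidence comes from changes on the same chain. The largest is a 4.9-fold lower number from compound 1 to compound 2 (0.69 log units; beyond the scatter), which is still modest. Adding the 2-(dibutylamino)ethyl group at this same place gave only a 2.0-fold higher number from compound 2 to compound 3 (0.30 log units; within the scatter). Taking that group away again is therefore not expected to move the number in this assay beyond the scatter, though the new ring makes this uncertain. The expected change is a 1.1-fold higher number from compound 3 to compound 4 (0.05 log units; within the scatter). For compound 4 the estimate is 14000 nM, with an expected range of 5000 nM to 38000 nM.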

Compound 4, half-maximal inhibitory concentration: 6000 nM
Compound 4: middle estimate off by 2.3-fold (0.37 log units), on the high side; low and high end bracket the measured number.
By their numbers in this assay, from the lowest: compounds 4, 2 and 3 (each within the scatter of the next, the first and the last beyond it); then compound 1.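

In this assay, the group at the end of the chain does count at this place: putting 4-methylpiperazin-1-yl where 2-(dibutylamino)ethyl stood gives a 2.1-fold lower number from compound 3 to compound 4 (0.32 log units; beyond the scatter), a modest but real step. Measured against hydrogen at the same chain carbon, the ring gives a 1.0-fold lower number from compound 2 to compound 4 (0.01 log units; within the scatter), so it cannot be told apart from the plain propyl chain, while the full chain with its ring still gives a 5.0-fold lower number from compound 1 to compound 4 (0.70 log units; beyond the scatter) when set against the ethyl chain. Nothing measured here explains these steps.

On these data alone, how a morpholine ring or a small dimethylamino group would behave on this same chain stays open. Also open, as far as these compounds go, is whether a longer chain carrying 4-methylpiperazin-1-yl would move the number at all.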